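A few compounds are considered here, and "the series" means these few. Any claim that something is new, unique, unknown or untested is made for them only; others in the source may bear on it.

Compound 1 `COc1ccc2ncc(-c3nn[nH]n3)cc2c1`: > 25 mg/kg in a functional assay on the whole organism (strain Sprague-Dawley) for inhibition, with Rattus norvegicus as the target; on this read-out lower numbers stand for an effect already at smaller amounts and higher numbers for an effect only at larger amounts of compound — a limit of the assay, not a number.
Compound 2 `O=c1c(-c2nn[nH]n2)c[nH]c2ccccc12`: > 20 mg/kg in this assay — again only a limit.

Compound 1 thus stands at no measured number at all; it sits at the limit of > 25 mg/kg in this assay, at which 1 of the 2 values shown sits. Compound 2 likewise sits only at the limit of > 20 mg/kg in this assay, at which 1 of the 2 values shown sits. Within the data shown here, with both measured compounds reported as limits, nothing in these data shows how far either of them would reach, and no step between measured compounds exists to lean on.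

Compound 3 `c1ccc2ncc(-c3nn[nH]n3)cc2c1` is the next compound to be tested. Compared with compound 1 it carries hydrogen in place of methoxy on an aromatic carbon. Among the measured compounds shown here, since no measured step is available, the size of this change in this assay is open; the account expects no shift beyond the usual scatter, and most likely a result that is again only a limit. Compound 3 is therefore expected to give about 40 mg/kg, within a range of 20 mg/kg to 100 mg/kg. The expected step is a step that the limit leaves unreadable from compound 1 to compound 3.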

Compound 3, minimum effective dose: 25 mg/kg
For compound 3 the middle estimate is 1.6-fold (0.20 log units) above the measured one; the range from low to high includes it.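

With hydrogen in place of methoxy on the aromatic carbon, this assay shows a number no higher from compound 1 to compound 3 (the limit leaves the size open). Compound 3 gives the first actual number among the compounds shown, 25 mg/kg. An effect can therefore be read at this position without the methoxy group, which neither earlier compound showed, as each gave only a limit. The size of this change cannot be read, because compound 1 is held only by a limit: the limit of > 25 mg/kg in this assay, at which 1 of the 3 values shown sits.

On these data alone, what an amine, a chlorine atom or a carboxylic acid on the same aromatic carbon would do in this assay stays open. As far as these compounds go, one measured number also sets no trend, and whether any change to the core of compound 3 would give an effect at a smaller dose remains unknown.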